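Replacing a Tetrazole on the Shared Core

The source may report more compounds than this note shows. Statements on the series, on what has been measured and on what is new or still open speak of the compounds shown alone.

Measured so far in an assay on HEK293 cells for inhibition of transient receptor potential cation channel subfamily M member 8 (Homo sapiens), read by FLIPR, with stated times of 5 min and 3 min; on this read-out higher numbers stand for weaker inhibition and lower numbers for stronger inhibition:
compound 1 `O=C(c1sc(-c2cccc(F)c2)nc1O)N1CCCCO1`: 167 nM
compound 2 `Oc1nc(-c2cccc(F)c2)sc1-c1nn[nH]n1`: > 100000 nM

Compound 1 gives a clear number in this assay. Compound 2, in contrast, gives only > 100000 nM, which is a limit of the assay and not a number. Going by the values given here, compound 2 thus stands at the limit of > 100000 nM in this assay, at which 1 of the 2 values shown sits, the weakest end of what this assay can report, and no measured step connects compound 2 to any other compound, so no step size is known from data.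

Compound 3 `CON(C)C(=O)c1sc(-c2cccc(F)c2)nc1O` differs from compound 2 in one place: methoxy(methyl)carbamoyl in place of 2H-tetrazol-5-yl on an aromatic carbon. Compound 1 also carries a carbonyl joined to a nitrogen that bears an oxygen, and compound 1 gives 167 nM in this assay. On that resemblance, the step is expected to be an at least 330-fold lower number from compound 2 to compound 3 (2.52 log units; beyond the scatter), a large gain in inhibition, well beyond the scatter of repeated measurements. Compound 3 is estimated at 300 nM in this assay, with a range from 60 nM to 2000 nM.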

Compound 3, half-maximal inhibitory concentration: 96 nM
For compound 3 the middle estimate is 3.1-fold (0.49 log units) above the measured one; measured number inside the range.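

Going by these compounds alone, the tetrazole result alone showed only that one group at this position gave no usable number, but now the position is seen to matter: in this assay, methoxy(methyl)carbamoyl in place of 2H-tetrazol-5-yl on the same aromatic carbon gives an at least 1000-fold lower number from compound 2 to compound 3 (3.01 log units; beyond the scatter). The true size of this step stays unknown because compound 2 gives a limit of the assay and not a number: the limit of > 100000 nM in this assay, at which 1 of the 3 values shown sits.

The group on the far side of the carbonyl also turns out to be open to change, as the open-chain group of compound 3 in place of the six-membered ring of compound 1 gives a 1.7-fold lower number from compound 1 to compound 3 (0.24 log units; within the scatter), so the ring shows no measurable advantage in this pair.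

What the compounds shown leave open is which part of the methoxy(methyl)carbamoyl group is needed, since a carboxylic acid or a dimethylcarbamoyl group on the same aromatic carbon would separate the carbonyl from the oxygen on the nitrogen. Going by these compounds, all three compounds also carry the hydroxy group on the ring, so the effect of an amine or a methoxy group in its place remains unknown.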